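The source may hold more compounds than are shown below. What is called first, only, known or untested is meant among the compounds shown, and "the series" means these compounds.

In a functional assay on MCF7 cells (Homo sapiens) for antiproliferative activity, read by CellTiter-Glo, with a stated time of 5 days (a higher number here means a weaker inhibitor, a lower number a stronger inhibitor), compound 1 `CC/C(=C(/c1ccc(/C=C/C(=O)O)cc1)c1ccc2c(cnn2C)c1)c1ccccc1` gives 300 nM. Compound 2 `CC/C(=C(/c1ccc(/C=C/C(=O)O)cc1)c1ccn2nccc2c1)c1ccccc1` sits at > 500 nM, which is a limit. Compound 3 `CC/C(=C(/c1ccc(/C=C/C(=O)O)cc1)c1ccc2nncn2c1)c1ccccc1` stands at > 500 nM, also a limit and not a number. Compound 4 `CC/C(=C(/c1ccc(/C=C/C(=O)O)cc1)c1ccc2scnc2c1)c1ccccc1` carries 1,3-benzothiazol-5-yl instead, and the change is a group of 9 heavy atoms (7 carbon, 1 nitrogen, 1 sulfur; one five-membered aromatic ring with 2 hetero atoms, one six-membered aromatic ring of carbon only) in place of a group of 9 heavy atoms (6 carbon, 3 nitrogen; one five-membered aromatic ring with 3 hetero atoms, one six-membered aromatic ring with 1 hetero atom), on a double-bonded chain carbon bound to an aromatic carbon and a double-bonded chain carbon. Among the measured compounds shown here, two measured steps bear on it: an at least 1.6-fold higher number from compound 1 to compound 2 (0.22 log units; that floor lies within the scatter), and an at least 1.6-fold higher number from compound 1 to compound 3 (0.22 log units; that floor lies within the scatter). Neither floor lies beyond the scatter, and a step that the two limits leave unreadable from compound 2 to compound 3 adds no size. Compound 1, at 300 nM, shares with compound 4 a six-membered aromatic ring of carbon only, so a modest move to a lower number is expected in this assay. The expected change is an at least 1.4-fold lower number from compound 3 to compound 4 (0.15 log units; that floor lies within the scatter). For compound 4 the estimate is 350 nM, with an expected range of 120 nM to 900 nM.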

Compound 4, half-maximal inhibitory concentration: 90 nM
Beside the measured number, compound 4's estimate is 3.9-fold (0.59 log units) above it; measured number below the stated range.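

In this assay, among the compounds shown here, 1,3-benzothiazol-5-yl on this double-bonded chain carbon gives a 3.3-fold lower number from compound 1 to compound 4 (0.52 log units; beyond the scatter), so this position answers to the choice of group, which the earlier compounds could not show. Against the two groups with a hetero atom in the six-membered ring, the change gives an at least 5.5-fold lower number from compound 3 to compound 4 (0.74 log units; beyond the scatter) and an at least 5.5-fold lower number from compound 2 to compound 4 (0.74 log units; beyond the scatter). Both sizes are floors and not exact steps: the limit of > 500 nM in this assay, at which 2 of the 4 values shown sit.

From the compounds shown here alone, it stays open how 1,3-benzoxazol-5-yl, with oxygen in place of the sulfur, would stand on this carbon. Going by these compounds, the sulfur's own share also stays open, as compound 1 and compound 4 differ in more than that atom.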